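The source may report more compounds than this note shows. Statements on the series, on what has been measured and on what is new or still open speak of the compounds shown alone.

Of the compounds shown here, three have so far been tested in a functional assay on the whole organism (strain albino) for inhibition, with Rattus norvegicus as the target, read by paw edema, with stated times of 30 min and 5 h, at a dose of 0.28 mmol/kg by the oral route; on this read-out higher numbers stand for more inhibition at the one dose given (going by the name of the read-out) and lower numbers for less inhibition. Compound 1, `COc1cc(-c2nnc(SCC(=O)Nc3ccc(/C(C)=N/O)cc3)n2-c2ccccc2)cc(OC)c1OC`, gives 70%. Compound 2, `CCn1c(SCC(=O)Nc2ccc(C(C)=O)cc2)nnc1-c1cc(OC)c(OC)c(OC)c1`, gives 64%. Compound 3, `COc1ccc(-c2nnc(SCC(=O)Nc3ccc(C(C)=O)cc3)n2-c2ccccc2)cc1`, gives 60%. The number for compound 3 is the smallest of the three, but its distance to compound 2 and to compound 1 lies in each case within the usual scatter of repeated measurements, so the three numbers cannot be told apart with any confidence.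

Compound 4 is `COc1cc(-c2nnc(SCC(=O)Nc3ccc(C(C)=O)cc3)n2-c2ccccc2)cc(OC)c1OC`, and it has not yet been measured. Compared with compound 3 the change is 3,4,5-trimethoxyphenyl in place of 4-methoxyphenyl on an aromatic carbon. Among the measured compounds shown here, no pair of measured compounds differs in only this one place, so the size of the effect has to be estimated indirectly. Compound 1 and compound 2 both carry the 3,4,5-trimethoxyphenyl group, and both give numbers that lie within the scatter of the number for compound 3. The expected step of a number 5 percentage points higher from compound 3 to compound 4 (within the scatter) in this assay is therefore small and upward, not beyond the scatter. For compound 4 the estimate is 65%, with a range from 55% to 75%.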

Compound 4, a percentage reported as inhibition, in the whole organism at one dose (the size of the read-out at that dose, not a potency): 63%
Estimate against measurement, compound 4: 2 percentage points above; the measured number falls inside the stated range.
By their numbers in this assay, from the lowest: compounds 3, 4, 2 and 1 (each within the scatter of the next).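

Read directly for the first time, 3,4,5-trimethoxyphenyl in place of 4-methoxyphenyl on the aromatic carbon of the five-membered ring gives a number 3 percentage points higher from compound 3 to compound 4 (within the scatter) in this assay, so the larger group at this position brings no difference that can be told from the scatter. The two other single changes around compound 4 also stay inside the scatter: phenyl in place of ethyl on the aromatic nitrogen gives a number 1 percentage points lower from compound 2 to compound 4 (within the scatter), and the group of 3 heavy atoms in place of the group of 4 heavy atoms on an aromatic carbon gives a number 7 percentage points lower from compound 1 to compound 4 (within the scatter), so none of the three places yet shows a clear effect on this read-out at this one dose. No measured information is at hand to explain these small steps.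

The compounds shown leave open whether this position would respond to a group of a different kind, such as a phenyl ring carrying an amine or a carboxylic acid in place of the methoxy groups. They also leave open what a longer chain on the ring nitrogen would do, and how these compounds would compare across several doses.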